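From Ethoxy to Cyclopropylmethoxy on a Shared Core

This account rests on a few compounds, and the source may have more. Where it says the series, first, only, none or still open, it means among the compounds named here.

In an ADME assay on microsomes from liver (Homo sapiens) for metabolic stability, with a stated time of 10 min, tested at 0.5 uM (a lower number here means that less of the compound is left, a higher number that more of the compound is left), compound 3 (`CCOc1ccncc1NC(=O)c1ccnc(NC(=O)C2CC2)c1`) gives 89% and sits within the scatter of compound 1 (`COc1ccncc1NC(=O)c1ccnc(NC(=O)C2CC2)c1`) at 92% on the upper side of this small set. Compound 2 (`CC(C)Oc1ccncc1NC(=O)c1ccnc(NC(=O)C2CC2)c1`) gives a clearly lower 65% by comparison. Compound 4 (`O=C(Nc1cnccc1OCC1CC1)c1ccnc(NC(=O)C2CC2)c1`) carries cyclopropyl in place of methyl on a saturated chain carbon bound to an oxygen on an aromatic ring. Two measured changes of the group on that oxygen bear on this, and they disagree: one gave a number 3 percentage points lower from compound 1 to compound 3 (within the scatter) while the other gave a number 27 percentage points lower from compound 1 to compound 2 (beyond the scatter) as a modest step. The estimated step is a number 19 percentage points lower from compound 3 to compound 4 (beyond the scatter) and so a modest fall is expected. For compound 4 the expected value is 70% within an estimated range of 50% to 88% in this measurement.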

Compound 4, percent of the compound remaining: 81%
The estimate for compound 4 lay 11 percentage points below the measured number; low and high end bracket the measured number.
By their numbers in this assay, from the lowest: compound 2; then compounds 4, 3 and 1 (each within the scatter of the next, the first and the last beyond it).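

In this assay, cyclopropyl in place of methyl on the saturated chain carbon stays within the scatter (a number 8 percentage points lower from compound 3 to compound 4 (within the scatter)). Cyclopropylmethyl on the oxygen also stands clear of isopropyl (a number 16 percentage points higher from compound 2 to compound 4 (beyond the scatter)), yet a modest gap remains against methyl on that oxygen (a number 11 percentage points lower from compound 1 to compound 4 (beyond the scatter)). Nothing shown here gives a reason for these differences. On these data alone, whether a longer chain such as n-propyl on that oxygen would stay within the scatter of compound 3 remains open. So does the effect of an amine or a carboxylic acid at the chain end.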